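A few compounds are considered here, and "the series" means these few. Any claim that something is new, unique, unknown or untested is made for them only; others in the source may bear on it.

Among the two compounds measured in an assay on cell membranes for binding affinity to 2-oxoglutarate receptor 1 (Rattus norvegicus), read by radioligand binding (on this read-out lower numbers stand for stronger inhibition and higher numbers for weaker inhibition), compound 2 `Nc1ncnc2c1ncn2C1O[C@H](C(=O)NC2CCCCCC2)[C@@H](O)[C@H]1O` stands lowest: compound 2 gives 22 nM, while compound 1 `NC(=O)[C@H]1OC(n2cnc3c(N)ncnc32)[C@H](O)[C@@H]1O` gives 64 nM. For the measured compounds named here, the one measured step, a 2.9-fold lower number from compound 1 to compound 2 (0.46 log units; beyond the scatter), came from putting cycloheptyl in place of hydrogen on an amide-type nitrogen. Compound 3 `CCONC(=O)[C@H]1OC(n2cnc3c(N)ncnc32)[C@H](O)[C@@H]1O` differs from compound 2 by ethoxy in place of cycloheptyl on an amide-type nitrogen, so the cycloheptyl that the step from compound 1 to compound 2 introduced is taken away again and an ethoxy is put on the same nitrogen. Going by the values given here, no measured step shows what an ethoxy on that nitrogen does; the only guidance is that losing the cycloheptyl, in the step from compound 1 to compound 2 read backwards, would return the number toward that of compound 1. The expected step is therefore a 2.3-fold higher number from compound 2 to compound 3 (0.36 log units; beyond the scatter), a modest rise. Compound 3 is estimated at 50 nM, within 18 nM to 140 nM.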

Compound 3, inhibition constant: 67 nM
Compound 3: middle estimate off by 1.3-fold (0.13 log units), on the low side; the measured number falls inside the stated range.
By their numbers in this assay, from the lowest: compound 2; then compounds 1 and 3 (each within the scatter of the next).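

In this assay, ethoxy in place of cycloheptyl on the amide-type nitrogen brings a 3.0-fold higher number from compound 2 to compound 3 (0.48 log units; beyond the scatter), so the lower number of compound 2 does not carry over to this other group on the same nitrogen. Set against the hydrogen of compound 1, ethoxy gives a 1.0-fold higher number from compound 1 to compound 3 (0.02 log units; within the scatter), which means that among these three compounds a group on this nitrogen does not by itself move the number, and only cycloheptyl does. No evidence is available on what lies behind this difference between the two groups.

From the compounds shown here alone, it remains open whether compound 2 owes its number to the ring or to the carbon count, which a straight heptyl chain on this nitrogen would address. An ethyl or cyclopentyl group there would likewise show how the number responds without the ethoxy oxygen.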